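Swapping the Group on the Thiocarbonyl Carbon

The compounds below may be only part of what the source reports. "The series", "measured", "known", "first", "only" and "open" are said of these compounds alone.

Three measured compounds share one core and differ only in the group on the thiocarbonyl carbon or in a substituent on it. Compound 1 `Nc1ccccc1NC(=O)c1ccc(CSC(=S)N2CCc3ccccc32)cc1` gives 25.7% in a functional assay on A-375 cells (Homo sapiens) for antiproliferative activity, read by CCK-8 assay, with a stated time of 72 h, tested at 2 uM; a higher number here means a stronger effect of the compound at the concentration tested, a lower number a weaker effect. Compound 2 `CN(C(=S)SCc1ccc(C(=O)Nc2ccccc2N)cc1)c1cccnc1` gives 26.5% in this assay, and compound 3 `Nc1ccccc1NC(=O)c1ccc(CSC(=S)N2CCc3cc(Cl)ccc32)cc1` gives 31.9% in this assay. Compound 3 stands highest of the three numbers, yet the step of a number 5.4 percentage points higher from compound 2 to compound 3 (within the scatter) and the step of a number 6.2 percentage points higher from compound 1 to compound 3 (within the scatter) both lie within the scatter, so compound 3 cannot be called the most active of the set.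

Compound 4 `CC1CCCCN1C(=S)SCc1ccc(C(=O)Nc2ccccc2N)cc1` has not been measured. It differs from compound 3 in one place: 2-methylpiperidin-1-yl in place of 5-chloro-2,3-dihydro-1H-indol-1-yl on a thiocarbonyl carbon. Two measured steps also exchange the group on the thiocarbonyl carbon, namely a number 0.8 percentage points higher from compound 1 to compound 2 (within the scatter) and a number 5.4 percentage points higher from compound 2 to compound 3 (within the scatter), and neither leaves the scatter. The remaining step, a number 6.2 percentage points higher from compound 1 to compound 3 (within the scatter), is within it as well. On this evidence, no change beyond the scatter is expected in this assay for compound 4, and the expected step is a number 5.9 percentage points lower from compound 3 to compound 4 (within the scatter). Compound 4 is therefore estimated at 26%, with a range from 16% to 36%.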

Compound 4, a percentage reported as inhibition, at one concentration (the size of the read-out at that concentration, not a potency): 42.5%
For compound 4 the middle estimate is 16.5 percentage points below the measured one; the whole stated range lies below it.
By their numbers in this assay, from the lowest: compounds 1, 2 and 3 (each within the scatter of the next); then compound 4.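

Among these compounds, until this result, no exchange of the group on the thiocarbonyl carbon had left the scatter in this assay, so this position could have seemed insensitive to such changes; 2-methylpiperidin-1-yl is the first group to show otherwise, with a number 10.6 percentage points higher from compound 3 to compound 4 (beyond the scatter) in place of 5-chloro-2,3-dihydro-1H-indol-1-yl. The same group also gives a number 16 percentage points higher from compound 2 to compound 4 (beyond the scatter) in place of methyl(pyridin-3-yl)amino and a number 16.8 percentage points higher from compound 1 to compound 4 (beyond the scatter) in place of 2,3-dihydro-1H-indol-1-yl, which makes compound 4 the only one of the four whose steps to all the others are printed as beyond the scatter. Its group is also the only one of the four without an aromatic ring, but a single compound cannot establish that as a pattern, and nothing available explains why this group stands apart.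

As far as these compounds go, whether the higher number belongs to the methyl group or to the non-aromatic ring itself stays open, and plain piperidin-1-yl, morpholin-4-yl or diethylamino on the same carbon would separate the two. With a read-out taken at one concentration, the numbers show only a stronger or weaker effect at that concentration.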